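A Cyclohexyl for Pentyloxy Exchange on an Aromatic Carbon

This account rests on a few compounds, and the source may have more. Where it says the series, first, only, none or still open, it means among the compounds named here.

Of the compounds shown here, three have been measured so far in a functional assay on brain (Rattus norvegicus, strain Wistar) for inhibition; on this read-out lower numbers stand for stronger inhibition and higher numbers for weaker inhibition. There compound 1 `Cc1[nH]c(=O)n(C)c1-c1ccc(C2CCCCC2)cc1` gives 10000 nM, compound 2 `CCCc1ccc(-c2c(C)[nH]c(=O)n2C2CCCCC2)cc1` gives 13900 nM and compound 3 `CCCCCOc1ccc(-c2c(C)[nH]c(=O)n2C2CCCCC2)cc1` gives 9100 nM. Compound 3 stands within the usual scatter of both other compounds, so the numbers set no order between it and either of them.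

The next compound is compound 4 `Cc1[nH]c(=O)n(C2CCCCC2)c1-c1ccc(C2CCCCC2)cc1`, which has cyclohexyl in place of pentyloxy on an aromatic carbon of a six-membered aromatic ring of carbon only, para to a large group: cyclohexyl in place of pentyloxy on an aromatic carbon. Within the data shown here, one measured step bears on this place, pentyloxy in place of propyl on an aromatic carbon, and it amounts to a 1.5-fold lower number from compound 2 to compound 3 (0.18 log units; within the scatter), which lies within the scatter. Cyclohexyl on such a carbon is also present in compound 1 at 10000 nM, though that compound differs from compound 4 in a second place. With so little evidence, no step beyond the scatter is expected in this assay. The expected change is a 1.0-fold lower number from compound 3 to compound 4 (0.00 log units; within the scatter). For compound 4 the estimated value is 9000 nM, with an expected range from 4000 nM to 20000 nM.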

Compound 4, half-maximal inhibitory concentration: 28900 nM
The estimate for compound 4 lay 3.2-fold (0.51 log units) below the measured number; measured number above the stated range.
By their numbers in this assay, from the lowest: compounds 3, 1 and 2 (each within the scatter of the next); then compound 4.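

In this assay, among these compounds, cyclohexyl on this aromatic carbon is the first group at the position to move the number beyond the scatter: the change is a 3.2-fold higher number from compound 3 to compound 4 (0.50 log units; beyond the scatter) and, against the propyl compound, a 2.1-fold higher number from compound 2 to compound 4 (0.32 log units; beyond the scatter) while pentyloxy and propyl had stayed within the scatter of each other (a 1.5-fold lower number from compound 2 to compound 3 (0.18 log units; within the scatter)). Pentyloxy and cyclohexyl have the same heavy-atom count, so that count does not account for the step, and with this carbon substituent held as cyclohexyl the aromatic nitrogen also responds, with cyclohexyl in place of methyl giving a 2.9-fold higher number from compound 1 to compound 4 (0.46 log units; beyond the scatter) and leaving compound 4 the weakest of the four, though each of these steps is modest. Nothing available explains why this exchange raises the number.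

The compounds shown leave open whether the step follows the entering ring or the departing oxygen, as both change together; a hexyl chain or a cyclohexyloxy group on this carbon would separate the two. They also leave open whether any group here, such as an amine or a carboxylic acid, could bring the number clearly below those of compounds 1, 2 and 3.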